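Shortening the Alkylamine Chain from Compound 2 to Compound 4

The source may report more compounds than this note shows. Statements on the series, on what has been measured and on what is new or still open speak of the compounds shown alone.

Compound 1 `COc1ccc(Nc2n[n+]([O-])c3ccccc3[n+]2[O-])cc1`: 600 nM
Compound 2 `CCCCCCCCNc1n[n+]([O-])c2ccccc2[n+]1[O-]`: 4900 nM
Compound 3 `CCN(CC)c1n[n+]([O-])c2ccccc2[n+]1[O-]`: > 17600 nM, a limit of the assay rather than a number

In a functional assay on MOLT-4 cells (Homo sapiens) for cytotoxicity, read by MTT assay, with a stated time of 48 h (a higher number here means a weaker inhibitor, a lower number a stronger inhibitor), compound 1 gives 600 nM and compound 2 gives 4900 nM, so compound 2 holds the higher of the two numbers, with compound 1 as its nearest neighbour and the gap between them beyond the usual scatter. Compound 3 sits only at the limit of > 17600 nM in this assay, at which 1 of the 3 values shown sits, which is a limit and not a number. Compound 4 `CCNc1n[n+]([O-])c2ccccc2[n+]1[O-]` has not yet been measured; it differs from compound 2 by hydrogen in place of hexyl on a saturated chain carbon, two bonds along the chain from a nitrogen on an aromatic ring. Within the data shown here, with no measured step to draw on, the step from compound 2 is expected to be a 1.8-fold higher number from compound 2 to compound 4 (0.26 log units; within the scatter), modest and toward a weaker inhibitor. Compound 4 is therefore estimated at 9000 nM, within a range from 3000 nM to 25000 nM.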

Compound 4, half-maximal inhibitory concentration: 3300 nM
Compound 4: the middle estimate sits 2.7-fold (0.44 log units) above what was measured; low and high end bracket the measured number.
By their numbers in this assay, from the lowest: compound 1; then compounds 4 and 2 (each within the scatter of the next). At a limit, above all of these: compound 3.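

In this assay, hydrogen in place of hexyl on this saturated chain carbon changes nothing that can be told from the scatter, with a 1.5-fold lower number from compound 2 to compound 4 (0.17 log units; within the scatter). The nitrogen itself proves more sensitive: hydrogen in place of ethyl on a nitrogen on an aromatic ring gives an at least 5.3-fold lower number from compound 3 to compound 4 (0.72 log units; beyond the scatter). That step rests on compound 3, whose value is a limit and not a number: the limit of > 17600 nM in this assay, at which 1 of the 4 values shown sits.

As far as these compounds go, whether a methyl or propyl chain on this nitrogen would read the same remains open. So does the effect of a terminal amine or carboxylic acid on the chain.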